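Series notes: methoxy removal on the aryl ring, oral inhibition

The source may hold more compounds than are shown below. What is called first, only, known or untested is meant among the compounds shown, and "the series" means these compounds.

Measured:
compound 1 `CCOC(=O)c1c(CSc2nccn2C)nc2cc(OC)c(OC)cc2c1-c1ccc(OC)c(OC)c1` — 60%
compound 2 `CCOC(=O)c1c(CSc2nccn2CC)nc2cc(OC)c(OC)cc2c1-c1ccc(OC)c(OC)c1` — 51%

Going by the values given here, in a functional assay on the whole organism for inhibition, with Rattus norvegicus as the target, at a dose of 50 mg/kg by the oral route (on this read-out higher numbers stand for more inhibition at the one dose given (going by the name of the read-out) and lower numbers for less inhibition), compound 1 gives 60% and compound 2 gives 51%; the only measured step, a number 9 percentage points lower from compound 1 to compound 2 (within the scatter), lies within the scatter, so compound 1 and compound 2 stand level on these numbers. Compound 3 `CCOC(=O)c1c(CSc2nccn2C)nc2cc(OC)c(OC)cc2c1-c1ccc(OC)cc1` differs from compound 1 by hydrogen in place of methoxy on an aromatic carbon. No measured step touches this ring, so nothing shown bears directly on the change; the one step shown concerns the chain on the aromatic nitrogen. The step of a number 5 percentage points lower from compound 1 to compound 3 (within the scatter) is therefore expected to stay within the scatter. For compound 3 the estimate is 55%, with a range of 35% to 75%.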

Compound 3, a percentage reported as inhibition, in the whole organism at one dose (the size of the read-out at that dose, not a potency): 64%
Beside the measured number, compound 3's estimate is 9 percentage points below it; the range from low to high includes it.
By their numbers in this assay, from the lowest: compounds 2, 1 and 3 (each within the scatter of the next, the first and the last beyond it).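

In this assay, 3,4-dimethoxyphenyl to 4-methoxyphenyl gives a number 4 percentage points higher from compound 1 to compound 3 (within the scatter). Going by these compounds alone, this is the first reading on the aryl ring, and it shows that this methoxy group, ortho to a methoxy group and meta to a large group, can be replaced by hydrogen without a step beyond the scatter. No supporting measurement explains this result.

Still open, on these data alone, is whether an amine or a carboxylic acid on this carbon would stay within the scatter. Also open, as far as these compounds go, is whether hydrogen in place of the remaining methoxy group would do so.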